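Single Enantiomer of a Cyclohexylsulfanyl Amide

The source may report more compounds than this note shows. Statements on the series, on what has been measured and on what is new or still open speak of the compounds shown alone.

Compound 3 `CC(C(=O)NCc1ccc(C(F)(F)F)cc1SC1CCCCC1)c1ccc(NS(C)(=O)=O)c(F)c1` gives 0.5 nM in an assay on CHO cells for antagonist activity at transient receptor potential cation channel subfamily V member 1 (Homo sapiens), read by FLIPR (on this read-out higher numbers stand for weaker inhibition and lower numbers for stronger inhibition), the lowest of the three numbers recorded, though the gaps are within the scatter. Compound 1 `CCC1CCN(c2cc(C(F)(F)F)ccc2CNC(=O)C(C)c2ccc(NS(C)(=O)=O)c(F)c2)CC1` gives 0.7 nM and compound 2 `CC(C(=O)NCc1ccc(C(F)(F)F)cc1OC1CCCCC1)c1ccc(NS(C)(=O)=O)c(F)c1` gives 0.7 nM in this assay. The steps of a 1.4-fold lower number from compound 1 to compound 3 (0.15 log units; within the scatter) and a 1.4-fold lower number from compound 2 to compound 3 (0.15 log units; within the scatter), like no change at the digits printed from compound 1 to compound 2 (within the scatter), are all within the scatter. Compound 4 `C[C@H](C(=O)NCc1ccc(C(F)(F)F)cc1SC1CCCCC1)c1ccc(NS(C)(=O)=O)c(F)c1` differs from compound 3 as follows: the two compounds have the same atoms and bonds; at least one stereo element is drawn with a configuration in one of them and without one in the other: 1 of 1 stereo elements differ; a stereocentre at a saturated chain carbon is drawn without a configuration in compound 3 and S in compound 4. No measured step addresses a stereocentre, so nothing shown bears directly on this change; the S form may be the active one, or the pair may separate little. Compound 4 is therefore expected to give 0.4 nM in this assay, with a range of 0.15 nM to 1.5 nM, a step of a 1.3-fold lower number from compound 3 to compound 4 (0.10 log units; within the scatter) that is estimated rather than measured.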

Compound 4, inhibition constant: 0.3 nM
The estimate for compound 4 lay 1.3-fold (0.12 log units) above the measured number; the range from low to high includes it.
By their numbers in this assay, from the lowest: compounds 4, 3, 1 and 2 (each within the scatter of the next, the first and the last beyond it).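

Among the compounds shown here, this is the first step at the stereocentre, and it gives a 1.7-fold lower number from compound 3 to compound 4 (0.22 log units; within the scatter) in this assay. Drawing the saturated chain carbon as S therefore keeps compound 4 within the scatter of compound 3, so the data show no separation from defining this centre. The pair differs in one respect only: the fact that one of compounds 3 and 4 is drawn with a defined configuration and the other without, at the place where they differ

On these data alone, how the R form compares with the S form remains open. Also open, as far as these compounds go, is whether an ethyl group in place of the methyl group at this stereocentre would give a similar number in this assay.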